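Benzamide to Aryl Urea on a Shared Oxadiazole-Free Core

The source may report more compounds than this note shows. Statements on the series, on what has been measured and on what is new or still open speak of the compounds shown alone.

Measured compounds:
compound 1, `O=C(Nc1cccc(-c2nc(-c3ccc(NC(=O)c4cccnc4)cc3Cl)no2)c1)c1ccccc1` — 12800 nM
compound 2, `CC(=O)Nc1ccc(S(=O)(=O)Nc2cccc(-c3nc(-c4ccc(NC(=O)c5cccnc5)cc4C(F)(F)F)no3)c2)cc1` — > 10000 nM

Of the compounds shown here, two sharing the same core have been tested in a functional assay on MDA-MB-231 cells (Homo sapiens) for antiproliferative activity, read by MTT assay, with a stated time of 72 h; a higher number here means a weaker inhibitor, a lower number a stronger inhibitor. Within the data shown here, compound 1 gives 12800 nM, the only plain number available. Among the measured compounds shown here, compound 2 reaches only a limit of the assay, > 10000 nM, so no number is known for it; the limit of > 10000 nM in this assay, at which 1 of the 2 values shown sits, is the one piece of evidence beside the value of compound 1. For the measured compounds named here, with a single number and a single limit, compound 1 stands on its own and no measured step can be described.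

Compound 3, `C#Cc1ccc(NC(=O)Nc2cccc(-c3nc(-c4ccc(NC(=O)c5cccnc5)cc4Cl)no3)c2)cc1`, has not yet been tested. It differs from compound 1 in one place: (4-ethynylphenyl)amino in place of phenyl on a carbonyl carbon. In effect the benzamido group of compound 1 becomes a ((4-ethynylphenyl)carbamoyl)amino group, which brings one further hydrogen-bond donor and a triple bond outside the aromatic rings.

Nothing measured here says how such a change moves the number. As an estimate, compound 3 is expected to be somewhat stronger than compound 1, a step of a 2.6-fold lower number from compound 1 to compound 3 (0.41 log units; beyond the scatter), which would lie beyond the usual scatter only at the more favourable end of the range. The expected value for compound 3 is 5000 nM, with a range from 1500 nM to 16000 nM.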

Compound 3, half-maximal inhibitory concentration: > 10000 nM
Compound 3: no number, only a limit; the forecaster's own chance of this, stated with the estimate: 20%; at least 2.0-fold (0.30 log units) between middle value and limit.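

In this assay compound 3 gives only a limit of the assay, > 10000 nM, not a number, so the step from compound 1 to compound 3 cannot be read. How far (4-ethynylphenyl)amino in place of phenyl on a carbonyl carbon moves the number, and in which direction, stays open, with most values resting at one limit: the limit of > 10000 nM in this assay, at which 2 of the 3 values shown sit.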